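Enlarging the ether group in a cytotoxicity series

The source may report more compounds than this note shows. Statements on the series, on what has been measured and on what is new or still open speak of the compounds shown alone.

Measured compounds:
compound 1 `CCOc1ccc(C(O)C2OC(=O)c3c(OC)cc(OC)cc32)cc1`: > 40000 nM
compound 2 `CCCCCCOc1ccc(C(O)C2OC(=O)c3c(OC)cc(OC)cc32)cc1`: > 40000 nM

Compound 1 `CCOc1ccc(C(O)C2OC(=O)c3c(OC)cc(OC)cc32)cc1` is the starting point. In an ADME assay on RAW264.7 cells (Mus musculus) for cytotoxicity, read by MTT assay, with a stated time of 24 h, in the presence of a further agent that is not named here (a higher number here means a weaker inhibitor, a lower number a stronger inhibitor), compound 1 gives > 40000 nM, which is a limit of the assay rather than a number. In this assay compound 2 `CCCCCCOc1ccc(C(O)C2OC(=O)c3c(OC)cc(OC)cc32)cc1` gives > 40000 nM, again a limit and not a number. The step that the two limits leave unreadable from compound 1 to compound 2 therefore cannot be read. Compound 3 `COc1cc(OC)c2c(c1)C(C(O)c1ccc(OCC3CCCCC3)cc1)OC2=O` differs from compound 1 by cyclohexyl in place of methyl on a saturated chain carbon bound to an oxygen on an aromatic ring. For the measured compounds named here, the only measured step, from compound 1 to compound 2, is the one that bears on this change, since it also enlarges the group carried by the ring oxygen, but its size stays unknown because of the limit of > 40000 nM in this assay, at which 2 of the 2 values shown sit. No step beyond the scatter can be expected in this assay in either direction. Compound 3 is expected to sit near 60000 nM, between 30000 nM and 150000 nM, most probably again reported as a limit. The step that the limit leaves unreadable from compound 1 to compound 3 is accordingly estimated to be negligible.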

Compound 3, half-maximal inhibitory concentration: > 40000 nM
Compound 3: no number, only a limit; the forecaster's own chance of this, stated with the estimate: 85%; the middle value is on the limit's open side.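

The steps from compound 3 to compound 1 and compound 2 cannot be read, because all three compounds give a limit and not a number: the limit of > 40000 nM in this assay, at which 3 of the 3 values shown sit. The compounds shown leave open how cytotoxic each one actually is, and whether changing the ether group makes any difference in this assay.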